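The source may report more compounds than this note shows. Statements on the series, on what has been measured and on what is new or still open speak of the compounds shown alone.

Measured in an ADME assay (liver) for metabolic stability, with Liver microsome (Homo sapiens) as the target, read by LC-MS, using microsomes and NADPH, with a stated time of 5 min, at 37 degrees C; a lower number here means slower removal, a higher number faster removal of the compound:
compound 1 `CCn1c([C@@H](C)NS(=O)(=O)c2ccc(Cl)cc2)nc2ccc(OC)cc21`: > 100 mL.min-1.g-1 (a limit)
compound 2 `CCn1c([C@@H](C)NS(=O)(=O)c2ccc(Cl)cc2)nc2cc(CO)ccc21`: 88 mL.min-1.g-1
compound 3 `CCn1c([C@@H](C)NS(=O)(=O)c2ccc(Cl)cc2)nc2cc(C(N)=O)ccc21`: < 5 mL.min-1.g-1 (a limit)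

Compound 1 is known only as a limit, > 100 mL.min-1.g-1. Still unmeasured is compound 4 `CCn1c([C@@H](C)NS(=O)(=O)c2ccc(Cl)cc2)nc2ccc(CN(C)C)cc21`, with (dimethylamino)methyl in place of methoxy on an aromatic carbon. For the measured compounds named here, no measured step makes this exchange. Going by the values given here, the one measured step, an at least 17-fold lower number from compound 2 to compound 3 (1.24 log units; beyond the scatter), places carbamoyl where hydroxymethyl stood. It bears only loosely, showing that a single exchange of groups can move the number strongly in this assay. The nearest numerical reference is compound 2 at 88 mL.min-1.g-1. The expected change, a moderately lower number, is an at least 2.2-fold lower number from compound 1 to compound 4 (0.34 log units; beyond the scatter). For compound 4 the estimate is 45 mL.min-1.g-1, with an expected range of 14 mL.min-1.g-1 to 130 mL.min-1.g-1.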

Compound 4, intrinsic clearance in microsomes: 30 mL.min-1.g-1
Estimate against measurement, compound 4: 1.5-fold (0.18 log units) above; the measured number falls inside the stated range.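

For the compounds shown here, the first measured change at the place held by methoxy, (dimethylamino)methyl in its stead, gives an at least 3.3-fold lower number from compound 1 to compound 4 (0.52 log units; beyond the scatter). Compound 4 stands at 30 mL.min-1.g-1 as a true number. The real size of the step stays unknown because compound 1 is held only at a limit: the limit of > 100 mL.min-1.g-1 in this assay, at which 1 of the 4 values shown sits.

The compounds shown leave open whether the amine nitrogen or the longer chain goes with the lower number. A plain propyl chain, a morpholine or a carboxylic acid at this place would separate these readings.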